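This account rests on a few compounds, and the source may have more. Where it says the series, first, only, none or still open, it means among the compounds named here.

Measured in a functional assay on the whole organism with Rattus norvegicus as the target; on this read-out lower numbers stand for an effect already at smaller amounts and higher numbers for an effect only at larger amounts of compound:
- compound 1 `CCOC(=O)C(=O)Nc1cccc(OC)c1C#N`: 55.5 mg/kg
- compound 2 `CCCNc1cccc(NC(=O)C(=O)OCC)c1C#N`: 0.7 mg/kg

Compound 2 holds the lower of the two numbers, 0.7 mg/kg. Compound 3 `CCCCNc1cccc(NC(=O)C(=O)OCC)c1C#N` differs from it by methyl in place of hydrogen on a saturated chain carbon, three bonds along the chain from a nitrogen on an aromatic ring, which takes the propyl on the nitrogen to butyl. Among the compounds with values here, the only measured step, a 79-fold lower number from compound 1 to compound 2 (1.90 log units; beyond the scatter), is large, but it puts propylamino in place of methoxy. Within the data shown here, no measured step changes the chain length, so that step gives neither size nor direction here, and no change beyond the scatter is expected in this assay. The expected step is a 1.3-fold higher number from compound 2 to compound 3 (0.11 log units; within the scatter). Compound 3 is estimated at 0.9 mg/kg, with an expected range from 0.25 mg/kg to 3 mg/kg.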

Compound 3, dose for half-maximal effect: 0.3 mg/kg
Estimate against measurement, compound 3: 3.0-fold (0.48 log units) above; the range from low to high includes it.
By their numbers in this assay, from the lowest: compound 3; then compound 2; then compound 1.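

In this assay, taking the propyl on the nitrogen to butyl gives a 2.3-fold lower number from compound 2 to compound 3 (0.37 log units; beyond the scatter), which shows that the chain length on this nitrogen still affects the dose once the amino group is in place. Measured against the methoxy starting point, butylamino in place of methoxy gives a 190-fold lower number from compound 1 to compound 3 (2.27 log units; beyond the scatter). Nothing available explains this shift. From the compounds shown here alone, it remains open whether a longer chain such as pentyl or hexyl would lower the number further, and how a branched chain such as isobutyl would compare with butyl.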